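Adding a fluoro to compound 2

The source may report more compounds than this note shows. Statements on the series, on what has been measured and on what is new or still open speak of the compounds shown alone.

In an ADME assay (liver) for pharmacokinetics, with Liver microsome (Homo sapiens) as the target, read by LC-MS, using microsomes, tested at 5 uM (a lower number here means slower removal, a higher number faster removal of the compound), the compounds measured so far read:
compound 1 `CNS(=O)(=O)Nc1cccc(Cc2c(C)c3ccc(Oc4ncccn4)cc3oc2=O)c1`: 20000 mL.min-1.g-1
compound 2 `CNS(=O)(=O)Nc1cccc(Cc2c(C)c3ccc(Oc4nccs4)cc3oc2=O)c1`: 24000 mL.min-1.g-1

Compound 2 at 24000 mL.min-1.g-1 stands level with compound 1 at 20000 mL.min-1.g-1 since the two numbers lie within the scatter of each other. Compound 3 `CNS(=O)(=O)Nc1cccc(Cc2c(C)c3ccc(Oc4nccs4)cc3oc2=O)c1F` differs from compound 2 in one place (fluoro in place of hydrogen on an aromatic carbon): fluoro in place of hydrogen on an aromatic carbon, ortho to a (methylsulfamoyl)amino group.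

For the measured compounds named here, only one measured step exists, a 1.2-fold higher number from compound 1 to compound 2 (0.08 log units; within the scatter) and it came from 1,3-thiazol-2-yl in place of pyrimidin-2-yl on an oxygen on an aromatic ring. That is a different group, so no measurement here tests a fluoro directly. It offers only a loose guide to how far this assay moves among these close relatives. No step beyond the scatter is therefore expected, and no direction can be named from these data. The estimated change is a 1.1-fold lower number from compound 2 to compound 3 (0.04 log units; within the scatter) and it is expected to stay small. For compound 3 the estimated value is 22000 mL.min-1.g-1 (expected range 11000 mL.min-1.g-1 to 42000 mL.min-1.g-1).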

Compound 3, intrinsic clearance in microsomes: 9000 mL.min-1.g-1
The estimate for compound 3 lay 2.4-fold (0.39 log units) above the measured number; the whole stated range lies above it.
By their numbers in this assay, from the lowest: compound 3; then compounds 1 and 2 (each within the scatter of the next).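

In this assay, a single fluoro in place of hydrogen on an aromatic carbon, ortho to a (methylsulfamoyl)amino group, gives a 2.7-fold lower number from compound 2 to compound 3 (0.43 log units; beyond the scatter) and is the only step shown here that lies beyond the scatter. The earlier pair, compound 1 and compound 2, differed only in the ring on the oxygen and stood within the scatter of each other, so the ring carrying the (methylsulfamoyl)amino group is the one place shown where a change has moved the number clearly, and it took only 1 heavy atom to do so. Nothing measured here tells what lies behind this lower number in compound 3.

From the compounds shown here alone, whether a chloro or a methyl on this same aromatic carbon would also lower the number, or whether the step belongs to the fluoro alone, stays open, as does the outcome of a fluoro on another carbon of this ring. Going by these compounds, it is equally open whether the same fluoro would give a step of similar size with a pyrimidin-2-yl on the oxygen, as in compound 1, in place of the 1,3-thiazol-2-yl of compound 3.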